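The source may hold more compounds than are shown below. What is called first, only, known or untested is meant among the compounds shown, and "the series" means these compounds.

Measured so far:
Compound 1 `COc1ccc(-c2nc(CSc3cccc(Br)c3)nc3ccsc23)cn1`: > 50000 nM
Compound 2 `O=S(=O)(Cc1nc(-c2ccoc2)c2sccc2n1)c1cccc(Cl)c1`: > 50000 nM
Compound 3 `COc1ccc(-c2nc(CSc3cccc(C(F)(F)F)c3)nc3ccsc23)cn1`: > 50000 nM

In an ADME assay on cells (Homo sapiens) for cytotoxicity, read by resazurin assay, with a stated time of 5 days (on this read-out higher numbers stand for lower toxicity in this test and lower numbers for higher toxicity in this test), compound 1 gives > 50000 nM, which is a limit of the assay and not a number. Compound 3 likewise sits at a limit with > 50000 nM. Compound 2 also gives a limit, > 50000 nM. So compound 1 stands nowhere precise: the limit of > 50000 nM in this assay, at which 3 of the 3 values shown sit.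

Compound 4 `COc1ccc(-c2nc(CSc3cc(Cl)ccc3Cl)nc3ccsc23)cn1` differs from compound 1 in one place: 2,5-dichlorophenyl in place of 3-bromophenyl on a sulfur. Among the measured compounds shown here, the only measured step that bears on it, a step that the two limits leave unreadable from compound 1 to compound 3, changes a group on the same ring and cannot be read in size, since both ends are limits. No step beyond the scatter is therefore expected in this assay, and a step that the limit leaves unreadable from compound 1 to compound 4 is an estimate, not a measurement. Compound 4 is expected to give about 60000 nM, between 25000 nM and 150000 nM, most likely again as a limit.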

Compound 4, half-maximal cytotoxic concentration: > 50000 nM
Compound 4: no number, only a limit; the forecaster's own chance of this, stated with the estimate: 85%; the middle value lies beyond the limit too.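

Compound 1 and compound 4 both sit at a limit of the assay and not at a number, so no step between them can be read: the limit of > 50000 nM in this assay, at which 4 of the 4 values shown sit.

The compounds shown leave open which change, if any, would give an actual number in this assay.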